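The source may report more compounds than this note shows. Statements on the series, on what has been measured and on what is new or still open speak of the compounds shown alone.

Compound 1 `CC(C)(Oc1ccccc1)C1OCC(C/C=C\CCC(=O)O)C(c2cccnc2)O1`: 75.9 nM
Compound 2 `CC(C)(Oc1ccccc1O)C1OCC(C/C=C\CCC(=O)O)C(c2cccnc2)O1`: 95.5 nM

Among the measured compounds shown here, in a functional assay for inhibition, with Homo sapiens as the target (a lower number here means tighter binding, a higher number weaker binding), compound 2 gives 95.5 nM and stands level with compound 1, the only other measured compound, since the gap between them lies within the scatter. The next compound, compound 3 `COc1ccc(OC(C)(C)C2OCC(C/C=C\CCC(=O)O)C(c3cccnc3)O2)c([N+](=O)[O-])c1`, carries 4-methoxy-2-nitrophenyl in place of 2-hydroxyphenyl on an oxygen on a saturated carbon. For the measured compounds named here, only one measured step bears on this aromatic ring, a 1.3-fold higher number from compound 1 to compound 2 (0.10 log units; within the scatter), and it is within the scatter. Going by the values given here, no measured compound carries a nitro or a methoxy group, so the data offer only weak guidance on this larger change. The step expected in this assay is therefore none beyond the scatter, and the estimate is a 1.1-fold lower number from compound 2 to compound 3 (0.03 log units; within the scatter). For compound 3 the expected value is 90 nM, with an estimated range of 30 nM to 270 nM.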

Compound 3, dissociation constant: 6.17 nM
For compound 3 the middle estimate is 15-fold (1.16 log units) above the measured one, outside the stated range (below it).
By their numbers in this assay, from the lowest: compound 3; then compounds 1 and 2 (each within the scatter of the next).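

In this assay this position, on an oxygen on a saturated carbon, turns out to be able to shift the number well beyond the scatter: 4-methoxy-2-nitrophenyl in place of 2-hydroxyphenyl gives a 15-fold lower number from compound 2 to compound 3 (1.19 log units; beyond the scatter) and, in place of phenyl, gives a 12-fold lower number from compound 1 to compound 3 (1.09 log units; beyond the scatter). The earlier change on this ring, hydroxy in place of hydrogen, stayed within the scatter, so the position had not yet shown that it responds at all, and what it now shows is a clear move to tighter binding. Nothing at hand accounts for the size of these steps.

The nitro and methoxy groups enter together, and the compounds shown leave open which of them, or whether only the pair, carries the step. Also open, from the compounds shown here alone, is how an amine or a nitrile in place of the nitro group would read in this assay.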